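The compounds below may be only part of what the source reports. "The series", "measured", "known", "first", "only" and "open" are said of these compounds alone.

Measured so far in a functional assay on trachea (Cavia porcellus); a lower number here means a stronger inhibitor, a higher number a weaker inhibitor:
Compound 1 `CCN1CC[C@@]2(OC)OC(N)=C(C#N)[C@@H](c3ccc(C)cc3)[C@@H]2C1`: 16800 nM
Compound 2 `CCCN1CC[C@@]2(OC)OC(N)=C(C#N)[C@@H](c3ccc(C)cc3)[C@@H]2C1`: 21000 nM
Compound 3 `CO[C@@]12CCN(C)C[C@H]1[C@H](c1ccc(-c3cccs3)cc1)C(C#N)=C(N)O2`: 13800 nM

The change methyl in place of hydrogen on a saturated chain carbon, two bonds along the chain from an amine nitrogen in a ring gives a 1.3-fold higher number from compound 1 to compound 2 (0.10 log units; within the scatter). The core of compound 3 is not the core of compound 1; the difference between the two cores is not broken down here, and the values of compound 1 and compound 3 lie within the scatter of each other.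

Compound 4 `CCN1CC[C@@]2(OC)OC(N)=C(C#N)[C@@H](c3ccc(-c4cccs4)cc3)[C@@H]2C1` has not yet been measured in this assay. It differs from compound 3 by methyl in place of hydrogen on a saturated chain carbon bound to an amine nitrogen in a ring. This is the same kind of change as that from compound 1 to compound 2, not the same: here the methyl enters on a saturated chain carbon bound to an amine nitrogen in a ring, whereas in compound 2 it enters on a saturated chain carbon two bonds along the chain from an amine nitrogen in a ring.

In this assay the step from compound 3 to compound 4 is expected to be a 1.2-fold higher number from compound 3 to compound 4 (0.08 log units; within the scatter), beside the earlier 1.3-fold higher number from compound 1 to compound 2 (0.10 log units; within the scatter), because the earlier step of a 1.3-fold higher number from compound 1 to compound 2 (0.10 log units; within the scatter) stayed within the scatter. Compound 4 is estimated at 16500 nM, with an expected range from 8000 nM to 35000 nM.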

Compound 4, half-maximal inhibitory concentration: 19800 nM
Estimate against measurement, compound 4: 1.2-fold (0.08 log units) below; the measured number falls inside the stated range.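

In this assay, methyl in place of hydrogen on a saturated chain carbon bound to an amine nitrogen in a ring gives a 1.4-fold higher number from compound 3 to compound 4 (0.16 log units; within the scatter), and the steps on the two cores do not differ: the same change on two cores in this assay, a 1.3-fold higher number (0.10 log units; within the scatter) from compound 1 to compound 2 and a 1.4-fold higher number (0.16 log units; within the scatter) from compound 3 to compound 4, 1.1-fold (0.06 log units) apart, within the scatter of two such steps Both steps stay within the scatter, so the series shows no dependence on the core, but with no step beyond the scatter, it does not show that any real effect carries over, and the methyl enters at different places in the two steps. Thiophen-2-yl in place of methyl on an aromatic carbon gives a 1.2-fold higher number from compound 1 to compound 4 (0.07 log units; within the scatter), also within the scatter.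

Still open, going by these compounds, is whether a longer chain or a benzyl group on the amine nitrogen in a ring would move the number beyond the scatter. The same question stands for a carboxylic acid or an amine in place of thiophen-2-yl on the aromatic carbon.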